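Capping a phenol: hydroxy to methoxy on the anilino ring

This account rests on a few compounds, and the source may have more. Where it says the series, first, only, none or still open, it means among the compounds named here.

Measured compounds:
- compound 1, `c1ccc(Nc2ccc(N3CC4CC(C3)N4)cn2)cc1`: 2.66 nM
- compound 2, `Oc1ccc(Nc2ccc(N3CC4CC(C3)N4)cn2)cc1`: 7.1 nM

Going by the values given here, in an assay on cell membranes for displacement of a labelled ligand from Neuronal acetylcholine receptor; alpha4/beta2 (Rattus norvegicus) (on this read-out lower numbers stand for stronger inhibition and higher numbers for weaker inhibition), compound 2 gives 7.1 nM, the highest of the two numbers measured so far; its nearest neighbour is compound 1 with 2.66 nM, reached by the step of a 2.7-fold higher number from compound 1 to compound 2 (0.43 log units; beyond the scatter). Compound 3, `COc1ccc(Nc2ccc(N3CC4CC(C3)N4)cn2)cc1`, differs from compound 2 by methyl in place of hydrogen on an oxygen on an aromatic ring. Among the compounds with values here, no measured step covers this exact change. Within the data shown here, the only step that touches the same part of the structure is a 2.7-fold higher number from compound 1 to compound 2 (0.43 log units; beyond the scatter), which shows that adding a hydroxy group moved the number modestly upward; capping that hydroxy with a methyl may undo part of that shift or leave it unchanged, and either outcome would stay within or close to the scatter. The expected step is therefore a 1.6-fold lower number from compound 2 to compound 3 (0.20 log units; within the scatter), a small move toward a lower number. Compound 3 is accordingly estimated at 4.5 nM, with a likely range from 1.5 nM to 14 nM.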

Compound 3, inhibition constant: 7.3 nM
The estimate for compound 3 lay 1.6-fold (0.21 log units) below the measured number, and the stated range covers the measured number.
By their numbers in this assay, from the lowest: compound 1; then compounds 2 and 3 (each within the scatter of the next).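

The finding of a 1.0-fold higher number from compound 2 to compound 3 (0.01 log units; within the scatter) in this assay means that methyl in place of the hydrogen on the oxygen leaves the number within the scatter, so hydroxy to methoxy brings no readable shift here. Methoxy in place of hydrogen on the aromatic carbon gives a 2.7-fold higher number from compound 1 to compound 3 (0.44 log units; beyond the scatter) and so lands on the same side of compound 1 as the hydroxy group does: among these three compounds, the higher number goes with having either oxygen group on the ring, whether or not that oxygen keeps its hydrogen. Nothing available here explains this result.

Still open, on these data alone, is whether a longer chain on this oxygen, such as ethoxy or benzyloxy, would stay level with compound 2 and compound 3. Also open, as far as these compounds go, is whether a group without this oxygen, such as an amine or a fluorine, would sit closer to compound 1.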